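Swapping the para hydroxy for a nitrile on the aryl oxazole

The source may report more compounds than this note shows. Statements on the series, on what has been measured and on what is new or still open speak of the compounds shown alone.

Compound 3 `O=C(CCCCCCc1ccccc1)c1ncc(-c2ccc(O)cc2)o1` gives the highest of the three numbers in an assay (Rattus norvegicus) for inhibition of Fatty-acid amide hydrolase 1 (Homo sapiens) (on this read-out higher numbers stand for weaker inhibition and lower numbers for stronger inhibition), at 140 nM. Compound 2 `Nc1ccc(-c2cnc(C(=O)CCCCCCc3ccccc3)o2)cc1` gives 90 nM, and compound 1 `O=C(CCCCCCc1ccccc1)c1ncc(-c2ccc([N+](=O)[O-])cc2)o1` gives 50 nM. Compound 4 `N#Cc1ccc(-c2cnc(C(=O)CCCCCCc3ccccc3)o2)cc1` differs from compound 3 by cyano in place of hydroxy on an aromatic carbon. For the measured compounds named here, two measured steps bear on this: a 2.8-fold higher number from compound 1 to compound 3 (0.45 log units; beyond the scatter) and a 1.6-fold higher number from compound 2 to compound 3 (0.19 log units; within the scatter). Replacing the hydroxy by a group that counts no hydrogen-bond donor resembles the reverse of the step from compound 1, so the number for compound 4 is expected to fall below that of compound 3, by about a 2.0-fold lower number from compound 3 to compound 4 (0.30 log units; within the scatter), modestly. Compound 4 is therefore estimated at 70 nM, within the range 30 nM to 200 nM.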

Compound 4, inhibition constant: 40 nM
Compound 4: the middle estimate sits 1.8-fold (0.24 log units) above what was measured; low and high end bracket the measured number.
By their numbers in this assay, from the lowest: compounds 4, 1, 2 and 3 (each within the scatter of the next, the first and the last beyond it).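

In this assay, cyano at this place, para to a large group, stands apart from hydroxy, with a 3.5-fold lower number from compound 3 to compound 4 (0.54 log units; beyond the scatter), while against nitro it gives a 1.3-fold lower number from compound 1 to compound 4 (0.10 log units; within the scatter), so those two cannot be told apart. It also stands apart from amino, with a 2.3-fold lower number from compound 2 to compound 4 (0.35 log units; beyond the scatter), a separation that nitro had not shown beyond the scatter. Nothing available explains these steps.

As far as these compounds go, whether a carboxylic acid, a methyl ester or a chlorine at this place would match cyano remains open. So does whether cyano keeps this standing with a shorter chain on the carbonyl.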